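The source may hold more compounds than are shown below. What is called first, only, known or untested is meant among the compounds shown, and "the series" means these compounds.

Working notes on the series. Compound 1 `Cc1ccc(S(=O)(=O)Nc2cccc([N+](=O)[O-])c2)cc1`, compound 2 `O=[N+]([O-])c1cccc(NS(=O)(=O)c2ccc(F)cc2)c1` and compound 3 `O=[N+]([O-])c1ccc(S(=O)(=O)Nc2ccc(F)cc2)cc1` have been measured in an ADME assay; compound 4 `Cc1ccc(NS(=O)(=O)c2ccc([N+](=O)[O-])cc2)cc1` has not. In this assay compound 1 gives 8.27. In this assay compound 2 gives 7.85. In this assay compound 3 gives 6.45, the lowest of the three numbers, with compound 2 its nearest neighbour and compound 1 the furthest from it.

One step joins two compounds that differ in a single place: a number 0.42 log units higher from compound 2 to compound 1 (beyond the scatter), the change being (methyl in place of fluoro on an aromatic carbon). Among the compounds with values here, compound 2 and compound 3 are built from the same atoms joined differently; the difference between the two cores is not broken down here, and their two values show only that compound 3 lies well under compound 2 in this assay.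

Compound 4 stands to compound 3 as methyl in place of fluoro on an aromatic carbon. The place is described in the same words as for the change from compound 2 to compound 1, so it is taken as the same change, now on the core of compound 3. The change has been measured only once, on the other core, so the carry-over is an assumption. The step from compound 3 to compound 4 in this assay is expected to be about a number 0.42 log units higher from compound 3 to compound 4 (beyond the scatter) because of a number 0.42 log units higher from compound 2 to compound 1 (beyond the scatter). Compound 4 is therefore expected to give about 6.87 in this assay. The expected range for compound 4 runs from 6.5 to 7.25.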

Compound 4, acid dissociation constant: 6.78
For compound 4 the middle estimate is 0.09 log units above the measured one; low and high end bracket the measured number.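

Methyl in place of fluoro on an aromatic carbon now shows a number 0.33 log units higher from compound 3 to compound 4 (beyond the scatter) in this assay, so the change moves the number in the same direction on both cores, and the two steps cannot be told apart: the same change on two cores in this assay, a number 0.42 log units higher (beyond the scatter) from compound 2 to compound 1 and a number 0.33 log units higher (beyond the scatter) from compound 3 to compound 4, 0.09 log units apart, within the scatter of two such steps. Within this series, that supports carrying the change between the core of compound 1 and the core of compound 4 as a step of the same direction and similar size. The support rests on two pairs of compounds only; it gives no reason for the shift, does not break down the difference between the two cores, and does not show that the step would hold on a further core.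

The compounds shown carry only methyl or fluoro at the changing place, so the effect of an amine, a carboxylic acid, a methoxy group or a longer chain there remains open. A nitro group stands on every compound shown, so it also remains open how the number in this assay would respond with a nitrile or a trifluoromethyl group in its stead, and whether the step seen here would survive such a replacement.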